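Carbonyl substituent steps in a three-compound series

The source may hold more compounds than are shown below. What is called first, only, known or untested is meant among the compounds shown, and "the series" means these compounds.

In an assay on membranes from HeLa cells for displacement of a labelled ligand from adenosine receptor A3 (Homo sapiens), read by scintillation counting, with a stated time of 180 min, tested at 1 uM (a higher number here means more inhibition at the concentration tested (going by the name of the read-out), a lower number less inhibition), compound 1 `COC(=O)C1=C(C)NC(=O)NC1c1ccoc1` gives 2%, compound 2 `CCCOC(=O)C1=C(C)NC(=O)NC1c1ccoc1` gives 11%, and compound 3 `CC1=C(C(=O)C2CC2)C(c2ccoc2)NC(=O)N1` gives 16%. Compound 3 holds the highest of the three numbers, though compound 2 sits within the scatter of it; the step of a number 14 percentage points higher from compound 1 to compound 3 (beyond the scatter) is the only one beyond the scatter, while a number 9 percentage points higher from compound 1 to compound 2 (within the scatter) and a number 5 percentage points higher from compound 2 to compound 3 (within the scatter) are not. Compound 4 `CCNC(=O)C1=C(C)NC(=O)NC1c1ccoc1` differs from compound 3 by ethylamino in place of cyclopropyl on a carbonyl carbon. The steps on this carbonyl carbon so far, a number 14 percentage points higher from compound 1 to compound 3 (beyond the scatter) and a number 5 percentage points higher from compound 2 to compound 3 (within the scatter), were small, and none of them placed an ethylamino group there. A small step, likely downward toward the numbers of compounds 1 and 2, is therefore expected, a number 8 percentage points lower from compound 3 to compound 4 (within the scatter). Compound 4 is estimated at 8%, between 0% and 22%.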

Compound 4, a percentage reported as inhibition, at one concentration (the size of the read-out at that concentration, not a potency): 1%
The estimate for compound 4 lay 7 percentage points above the measured number; the range from low to high includes it.
By their numbers in this assay, from the lowest: compounds 4, 1, 2 and 3 (each within the scatter of the next, the first and the last beyond it).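

On this carbonyl carbon, ethylamino in place of cyclopropyl gives, in this assay, a number 15 percentage points lower from compound 3 to compound 4 (beyond the scatter), so this change undoes the one step that a number 14 percentage points higher from compound 1 to compound 3 (beyond the scatter) had shown beyond the scatter. Against the other two groups the change reads a number 10 percentage points lower from compound 2 to compound 4 (within the scatter) and a number 1 percentage points lower from compound 1 to compound 4 (within the scatter), which leaves ethylamino level with propoxy and methoxy and cyclopropyl the only group set apart, and then only from methoxy and ethylamino.

Going by these compounds, whether a cyclobutyl ring or a longer chain on this carbonyl carbon holds the number of compound 3, and whether a dimethylamino group behaves like ethylamino, stays open. No measurement at hand explains why cyclopropyl differs from ethylamino here.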